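The source may report more compounds than this note shows. Statements on the series, on what has been measured and on what is new or still open speak of the compounds shown alone.

The measured compounds:
compound 1, `COCCCn1c(=O)[nH]c2c(N)nc(C(F)(F)F)cc21`, gives 23 ug/mL in a physicochemical assay for solubility; a higher number here means a more soluble compound, a lower number a less soluble compound;
compound 2, `Nc1nc(C(F)(F)F)cc2c1[nH]c(=O)n2CC1CCCOC1`, gives 37 ug/mL in this assay;
compound 3, `Cc1cccc(Cn2c(=O)[nH]c3c(N)nc(C(F)(F)F)cc32)n1`, gives 3 ug/mL in this assay.

Compound 2 stands highest of the three numbers, although the step of a 1.6-fold higher number from compound 1 to compound 2 (0.21 log units; within the scatter) is within the scatter, so compound 1 and compound 2 cannot be told apart. The step of a 12-fold lower number from compound 2 to compound 3 (1.09 log units; beyond the scatter) is the one clear difference, and a 7.7-fold lower number from compound 1 to compound 3 (0.88 log units; beyond the scatter) points the same way.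

Compound 4, `Cc1ncc(Cn2c(=O)[nH]c3c(N)nc(C(F)(F)F)cc32)cn1`, differs from compound 2 in one place: 2-methylpyrimidin-5-yl in place of oxan-3-yl on a saturated chain carbon bound to an aromatic nitrogen. Among the compounds with values here, the change resembles the one from compound 2 to compound 3, where a six-membered aromatic ring carrying a methyl group entered at the same place and the number fell beyond the scatter, as a 12-fold lower number from compound 2 to compound 3 (1.09 log units; beyond the scatter) shows. On that basis a drop of similar size is expected for compound 4 in this assay, namely a 7.4-fold lower number from compound 2 to compound 4 (0.87 log units; beyond the scatter). Compound 4 is therefore estimated at 5 ug/mL, with a range from 2 ug/mL to 15 ug/mL.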

Compound 4, solubility: 152 ug/mL
Estimate against measurement, compound 4: 30-fold (1.48 log units) below; the measured number lies above the stated range.
By their numbers in this assay, from the lowest: compound 3; then compounds 1 and 2 (each within the scatter of the next); then compound 4.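

At this place, on a saturated chain carbon bound to an aromatic nitrogen, a six-membered aromatic ring carrying a methyl group does not by itself bring a low number in this assay: exchanging 6-methylpyridin-2-yl for 2-methylpyrimidin-5-yl gives a 51-fold higher number from compound 3 to compound 4 (1.70 log units; beyond the scatter). The 2-methylpyrimidin-5-yl group also stands above both non-aromatic groups, with a 4.1-fold higher number from compound 2 to compound 4 (0.61 log units; beyond the scatter) against oxan-3-yl and a 6.6-fold higher number from compound 1 to compound 4 (0.82 log units; beyond the scatter) against 2-methoxyethyl, so aromatic groups here reach both the lowest and the highest numbers seen. Nothing available explains why the two aromatic groups differ so widely.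

These two groups differ in several features at once, so the compounds shown cannot single out the feature that matters. As far as these compounds go, how a pyrimidin-5-yl ring without its methyl group or a chain ending in an amine would behave at this place remains open.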